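The source may hold more compounds than are shown below. What is called first, only, known or untested is meant among the compounds shown, and "the series" means these compounds.

Measured so far in a functional assay on MCF7 cells (Homo sapiens) for cytotoxicity, read by MTT assay, with a stated time of 72 h; on this read-out lower numbers stand for stronger inhibition and higher numbers for weaker inhibition:
compound 1 `COc1ccc(/C=C/C(=O)Nc2cc3c(Nc4ccc(F)c(Cl)c4)ncnc3cc2O[C@H]2CCOC2)c(OC)c1` – 28600 nM
compound 2 `COc1ccc(/C=C/C(=O)Nc2cc3c(Nc4ccc(F)c(Cl)c4)ncnc3cc2OC)c(OC)c1` – 36600 nM

Compound 1 gives the lowest of the two numbers; the nearest is compound 2, and a 1.3-fold higher number from compound 1 to compound 2 (0.11 log units; within the scatter) lies within the scatter. Compound 3 `COc1ccc(/C=C/C(=O)Nc2cc3c(Nc4ccc(F)c(Cl)c4)ncnc3cc2O[C@H]2CCOC2)cc1` differs from compound 1 by hydrogen in place of methoxy on an aromatic carbon. Among the compounds with values here, the only measured step concerns a different place on the molecule, so no measured step bears on this change, and the series shows nothing on removing a methoxy here. On that basis no step beyond the scatter in this assay is expected. Compound 3 is estimated at 28000 nM, within a range of 11000 nM to 70000 nM. For compound 3 this means an expected step of a 1.0-fold lower number from compound 1 to compound 3 (0.01 log units; within the scatter).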

Compound 3, half-maximal inhibitory concentration: 5070 nM
Compound 3: the middle estimate sits 5.5-fold (0.74 log units) above what was measured; the measured number lies below the stated range.
By their numbers in this assay, from the lowest: compound 3; then compounds 1 and 2 (each within the scatter of the next).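

In this assay, within the data shown here, the change from 2,4-dimethoxyphenyl to 4-methoxyphenyl gives a 5.6-fold lower number from compound 1 to compound 3 (0.75 log units; beyond the scatter), the first step beyond the scatter. This aromatic carbon therefore affects the read-out, and a lone hydrogen there is better tolerated than methoxy. No available evidence accounts for this step. From the compounds shown here alone, it remains open whether a fluorine, an amine or a longer alkoxy chain on this carbon would keep the lower number. Also open, going by these compounds, is whether the step carries over when methyl replaces oxolan-3-yl on the oxygen.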